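Cyclopropylsulfonyl for pentylcarbonyl on the amine nitrogen

This account rests on a few compounds, and the source may have more. Where it says the series, first, only, none or still open, it means among the compounds named here.

Measured so far in an ADME assay on microsomes from liver (Mus musculus) for metabolic stability, read by LC-MS, with NADPH named in the record, with a stated time of 60 min, tested at 1 uM, in the absence of a further agent; a higher number here means that more of the compound is left, a lower number that less of the compound is left:
compound 1, `COc1ccc(-c2c(C)nc3c(N4CC[C@@H](NC(C)=O)C4)cc(C)nn23)cc1F`: > 95%
compound 2, `CSc1ccc(-c2c(C)nc3c(N4CC[C@@H](NC(C)=O)C4)cc(C)nn23)cc1`: > 95%
compound 3, `CCCCCC(=O)N[C@@H]1CCN(c2cc(C)nn3c(-c4ccc(OC)c(OC)c4)c(C)nc23)C1`: > 95%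

Each of these is a limit of this assay, not a number. Compound 3 therefore gives only a limit, and it stands at the limit of > 95% in this assay, at which 3 of the 3 values shown sit. Compound 4, `COc1ccc(-c2c(C)nc3c(N4CC[C@@H](NS(=O)(=O)C5CC5)C4)cc(C)nn23)cc1OC`, is not yet measured in this assay; it differs from compound 3 by cyclopropylsulfonyl in place of pentylcarbonyl on an amine nitrogen. Among the compounds with values here, the one measured step, a step that the two limits leave unreadable from compound 1 to compound 2, runs between two limits and changes a group on an aromatic carbon, so no measured step bears on a change on the amine nitrogen. The step of a number no higher from compound 3 to compound 4 (the limit leaves the size open) is expected to lie within the scatter. Compound 4 is expected to remain at the limit, estimated at 95%, in the range 80% to 99%.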

Compound 4, percent of the compound remaining: > 95%
Compound 4 was reported as a limit; the forecaster's own chance of this, stated with the estimate: 70%; the middle value lies on the limit itself.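

Compound 3 and compound 4 are both reported only as limits, so the step between them cannot be read. The compounds shown leave open whether cyclopropylsulfonyl and pentylcarbonyl on the amine nitrogen differ at all in this assay.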